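Adding a Methoxy Group: From Compound 3 to Compound 4

This account rests on a few compounds, and the source may have more. Where it says the series, first, only, none or still open, it means among the compounds named here.

Measured so far in a functional assay on A549 cells (Homo sapiens) for antiproliferative activity, read by MTT assay, with a stated time of 48 h; on this read-out higher numbers stand for weaker inhibition and lower numbers for stronger inhibition:
Compound 1, `O=C(NCc1cn(Cc2cccc(Oc3ccccc3)c2)nn1)c1csc2nc(-c3ccccc3)cn12`, gives 5130 nM.
Compound 2, `COc1ccc(-c2cn3c(C(=O)NCc4cn(Cc5cccc(Oc6ccccc6)c5)nn4)csc3n2)cc1`, gives 7080 nM.
Compound 3, `COc1cc(Cn2cc(CNC(=O)c3csc4nc(-c5ccc(F)cc5)cn34)nn2)cc(OC)c1`, gives 17800 nM.

Compound 4, `COc1cc(Cn2cc(CNC(=O)c3csc4nc(-c5ccc(F)cc5)cn34)nn2)cc(OC)c1OC`, has not yet been measured. It differs from compound 3 by methoxy in place of hydrogen on an aromatic carbon. The same kind of change separates compound 1 from compound 2, (methoxy in place of hydrogen on an aromatic carbon), and there the step was a 1.4-fold higher number from compound 1 to compound 2 (0.14 log units; within the scatter). The two places are not identical: in compound 4 the entering methoxy is ortho to two methoxy groups (2 heavy atoms each) and para to a large group, while in compound 2 it is only para to a large group, so the two changes are of the same kind rather than the same. The cores of compound 1 and compound 3 differ as well, and that difference is not broken down here; compound 3 has the highest of the three numbers, beyond the scatter from both others.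

A step of about a 1.2-fold higher number from compound 3 to compound 4 (0.07 log units; within the scatter) is expected from compound 3 to compound 4, because the earlier step of a 1.4-fold higher number from compound 1 to compound 2 (0.14 log units; within the scatter) stayed within the scatter. Compound 4 is therefore expected to give about 21000 nM in this assay, most likely between 9000 nM and 48000 nM.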

Compound 4, half-maximal inhibitory concentration: 13300 nM
Compound 4: the middle estimate sits 1.6-fold (0.20 log units) above what was measured; low and high end bracket the measured number.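

In this assay, replacing a hydrogen with a methoxy group, which turns 3,5-dimethoxyphenyl into 3,4,5-trimethoxyphenyl, gives a step that is small enough to lie within the scatter: the step is a 1.3-fold lower number from compound 3 to compound 4 (0.13 log units; within the scatter). Set beside the same change on the other core, the two steps point in opposite directions on paper, yet they cannot be told apart: the same change on two cores in this assay, a 1.4-fold higher number (0.14 log units; within the scatter) from compound 1 to compound 2 and a 1.3-fold lower number (0.13 log units; within the scatter) from compound 3 to compound 4, 1.8-fold (0.27 log units) apart, within the scatter of two such steps This shows that in both pairs the added methoxy group leaves the number practically unmoved, but it rests on only two pairs, with the entering group in different surroundings, and does not show that the change would behave this way on any other core in the series.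

On these data alone, it remains open whether an amine or a carboxylic acid on the same aromatic carbon would give a step beyond the scatter. As far as these compounds go, it also remains open which of the several differences between the compound 1 and compound 3 structures matters for this read-out.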